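The compounds below may be only part of what the source reports. "The series", "measured", "known", "first", "only" and "open" are said of these compounds alone.

In an ADME assay on J774 cells (Mus musculus) for cytotoxicity (on this read-out higher numbers stand for an effect only at larger amounts of compound and lower numbers for an effect already at smaller amounts), compound 3 `CCCCC#Cc1c(C)[nH]c2ccc(OC)cc2c1=O` gives > 36800 nM, which is a limit and not a number. Compound 1 `COc1ccc2[nH]c(C)c(Br)c(=O)c2c1`, which carries bromo in place of hex-1-yn-1-yl, also gives a limit, > 37300 nM. That swap shows a step that the two limits leave unreadable from compound 1 to compound 3, so it offers no guide to size. Compound 2 `Cc1[nH]c2ccc(Cl)cc2c(=O)c1Br` gives 21700 nM.

Compound 4 `CCCCC#Cc1c(C)[nH]c2ccc(Cl)cc2c1=O` has chloro in place of methoxy on an aromatic carbon. The only measured case of this change is an at least 1.7-fold lower number from compound 1 to compound 2 (0.23 log units; that floor lies within the scatter), so a modest fall in the number is expected, though the evidence is thin. Estimated, that means an at least 1.8-fold lower number from compound 3 to compound 4 (0.26 log units; that floor lies within the scatter). Compound 4 is expected at 20000 nM, within an estimated range from 9000 nM to 37000 nM.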

Compound 4, half-maximal effective concentration in the J774 assay: > 36300 nM
Compound 4 ended at the assay's limit (the forecaster's own chance of this, stated with the estimate: 35%); middle value at least 1.8-fold (0.25 log units) away from the limit.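

In the J774 assay, chloro in place of methoxy on the hex-1-yn-1-yl compounds leaves compound 4 with only a limit and not a number, so this step and the other steps between limits cannot be read. With chloro held in place, hex-1-yn-1-yl in place of bromo gives, in the J774 assay, an at least 1.6-fold higher number from compound 2 to compound 4 (0.22 log units; that floor lies within the scatter). In a physicochemical assay for lipophilicity, at pH 7.4 (on this read-out lower numbers stand for lower lipophilicity and higher numbers for higher lipophilicity), compound 3 gives 5.25 and compound 4 gives 2.98. The methoxy to chloro change does register in the physicochemical assay: the measured distribution coefficient of compound 3, 5.25, and of compound 4, 2.98, a number 2.27 log units lower (beyond the scatter).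

Where compound 3 and compound 4 would give a true number stays open. Also open, as far as these compounds go, is whether an amine or carboxylic acid in place of chloro, or a longer chain in place of hex-1-yn-1-yl, would give an effect at smaller amounts in the J774 assay.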